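The compounds below may be only part of what the source reports. "The series", "measured", "known", "first", "only" and "open" are said of these compounds alone.

Measured in a functional assay on MGC-803 cells (Homo sapiens) for inhibition, read by MTT assay, with a stated time of 72 h; on this read-out higher numbers stand for weaker inhibition and lower numbers for stronger inhibition:
- compound 1, `O=C(CSc1nc(Nc2ccccc2)c2ccccc2n1)Nc1ccccc1Cl`: compound 1 gives 24800 nM
- compound 2, `O=C(CSc1nc(Nc2ccccc2)c2ccccc2n1)Nc1ccccc1Br`: compound 2 gives 18600 nM
- compound 3, `O=C(CSc1nc(Nc2ccccc2)c2ccccc2n1)Nc1cccc(Br)c1`: compound 3 gives 9620 nM

Compound 3 has the lowest number of the three, with the step of a 1.9-fold lower number from compound 2 to compound 3 (0.29 log units; within the scatter) and the step of a 2.6-fold lower number from compound 1 to compound 3 (0.41 log units; beyond the scatter). Compound 4, `CCc1cccc(NC(=O)CSc2nc(Nc3ccccc3)c3ccccc3n2)c1`, differs from compound 3 by ethyl in place of bromo on an aromatic carbon. For the measured compounds named here, no measured step exchanges a halogen for an alkyl group at this position; the only substituent exchange at a fixed place is a 1.3-fold lower number from compound 1 to compound 2 (0.12 log units; within the scatter), which stayed within the scatter. The bromo-to-ethyl change is therefore expected to leave the number close to that of compound 3, with no step beyond the scatter, the expected step being a 1.0-fold lower number from compound 3 to compound 4 (0.01 log units; within the scatter). Compound 4 is estimated at 9500 nM, within the range 4000 nM to 25000 nM.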

Compound 4, half-maximal inhibitory concentration: 15800 nM
Compound 4: the middle estimate sits 1.7-fold (0.22 log units) below what was measured, and the stated range covers the measured number.
By their numbers in this assay, from the lowest: compounds 3, 4, 2 and 1 (each within the scatter of the next, the first and the last beyond it).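

In this assay ethyl in place of bromo on this aromatic carbon gives a 1.6-fold higher number from compound 3 to compound 4 (0.22 log units; within the scatter) and so a halogen-to-alkyl exchange here stays within the scatter. The other new steps, a 1.2-fold lower number from compound 2 to compound 4 (0.07 log units; within the scatter) and a 1.6-fold lower number from compound 1 to compound 4 (0.20 log units; within the scatter) also lie within it, which leaves compound 4 unseparated from all three earlier compounds, although compound 1 and compound 3 are separated. No evidence bears on the reason for these numbers.

As far as these compounds go, whether an amine, a carboxylic acid or a longer chain such as butyl at this place would move the number beyond the scatter stays open. Also open, from the compounds shown here alone, is how 2-ethylphenyl would compare with 3-ethylphenyl on the amide-type nitrogen.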